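Methoxy in place of methylsulfanyl: notes on compound 4

The source may report more compounds than this note shows. Statements on the series, on what has been measured and on what is new or still open speak of the compounds shown alone.

Growth data from a functional assay on MV4-11 cells (Homo sapiens) for inhibition, read by resazurin assay, with a stated time of 72 h; on this read-out higher numbers stand for weaker inhibition of growth and lower numbers for stronger inhibition of growth:
- compound 1 `CCn1cc(-c2ccnc(Nc3ccc(OC)cc3OC)n2)c2ccccc21` gives 3590 nM
- compound 2 `COc1ccc(Nc2nccc(-c3sc(SC)nc3C)n2)c(OC)c1` gives 530 nM
- compound 3 `Oc1ccccc1Nc1nccc(-c2c[nH]c3ccccc23)n1` gives 570 nM

Compound 2 and compound 3 lie within the scatter of each other, while compound 1 stands beyond the scatter on the weaker side of compound 2. Among the compounds with values here, these three compounds differ in more than one place, so no measured step is available as a guide.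

Compound 4 `COc1ccc(Nc2nccc(-c3sc(OC)nc3C)n2)c(OC)c1` is still unmeasured. It carries methoxy in place of methylsulfanyl on an aromatic carbon, next to the ring nitrogen and next to the ring sulfur.

The expectation rests on compound 2 (530 nM) as the only close reference. In this assay, no change beyond the scatter is expected, with a slight drift towards a higher number at most. The expected step of a 1.3-fold higher number from compound 2 to compound 4 (0.12 log units; within the scatter) is an estimate and remains within the scatter. For compound 4 the expected value is 700 nM (estimated range 250 nM to 2000 nM).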

Compound 4, concentration for 50% growth inhibition: 1400 nM
The estimate for compound 4 lay 2.0-fold (0.30 log units) below the measured number, within the range that was stated.
By their numbers in this assay, from the lowest: compounds 2 and 3 (each within the scatter of the next); then compound 4; then compound 1.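

In this assay, within the data shown here, the replacement of methylsulfanyl by methoxy on an aromatic carbon of the five-membered ring gives a 2.6-fold higher number from compound 2 to compound 4 (0.42 log units; beyond the scatter), the first one-place step in this set, and it shows that growth inhibition responds to the atom exchanged at this position. The two groups match in heavy-atom count, hydrogen-bond donors, hydrogen-bond acceptors and net charge, so these counts alone do not predict the step. Nothing measured here accounts for the loss.

On these data alone, with a single step at this carbon, it remains open whether sulfur in the attached group matters in general or whether this result is specific to the methoxy and methylsulfanyl pair. Ethylsulfanyl, a dimethylamino group or a carboxylic acid at the same carbon would help to define how much this position tolerates.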